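This account rests on a few compounds, and the source may have more. Where it says the series, first, only, none or still open, it means among the compounds named here.

Compound 1 `O=C(Nc1ccccc1O)c1nccc2ccccc12` stands only at a limit in the numbers shown: in a functional assay on NUGC-3 cells (Homo sapiens) for inhibition, read by sulforhodamine B assay, with a stated time of 48 h (a lower number here means a stronger inhibitor of growth, a higher number a weaker inhibitor of growth), compound 1 gives > 10000 nM, which is a limit of the assay and not a number. Compound 2 `COc1ccc(NC(=O)C2NCCc3ccccc32)cc1` gives > 10000 nM in this assay, again a limit. Compound 3 `O=C(Nc1cccc(C(F)(F)F)c1)c1nccc2ccccc12` gives > 10000 nM in this assay, also a limit. Within the data shown here, no step between measured compounds can be set out; what the data show is the limit of > 10000 nM in this assay, at which 3 of the 3 values shown sit. Compound 4 `O=C(Nc1ccccc1Cl)c1nccc2ccccc12` differs from compound 1 by chloro in place of hydroxy on an aromatic carbon. With every measured value at the limit, no direction in this assay can be read from them, and the step that the limit leaves unreadable from compound 1 to compound 4 is expected to be none beyond the scatter. Compound 4 is therefore estimated at 15000 nM, within 5000 nM to 50000 nM.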

Compound 4, concentration for 50% growth inhibition: > 10000 nM
Compound 4 was reported as a limit (the forecaster's own chance of this, stated with the estimate: 80%); the middle value does not contradict the limit.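

No new step can be read between compound 1 and compound 4, as both stand only at a limit: the limit of > 10000 nM in this assay, at which 4 of the 4 values shown sit.

The compounds shown leave open which structural change, if any, would bring a measurable value in this assay.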